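The compounds below may be only part of what the source reports. "The series", "measured", "known", "first", "only" and "open" are said of these compounds alone.

Measured compounds in an ADME assay on cells (Homo sapiens) for cytotoxicity, read by polymerase chain reaction, with a stated time of 3 days; on this read-out higher numbers stand for lower toxicity in this test and lower numbers for higher toxicity in this test:
compound 1, `Nc1nc(Cl)c(-c2ccco2)c(N[C@@H]2C[C@H](CO)[C@@H](O)[C@H]2O)n1`: > 25000 nM, a limit of the assay.
compound 2, `COc1ccc2nc(-c3c(Cl)nc(N)nc3N[C@@H]3C[C@H](CO)[C@@H](O)[C@H]3O)sc2c1`: > 25000 nM, a limit of the assay.
compound 3, `Cc1nc(NCC2CCC2)nc(N[C@@H]2C[C@H](CO)[C@@H](O)[C@H]2O)c1-c1nc2ccccc2s1`: > 25000 nM, a limit of the assay.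

Compound 3 thus stands at the assay limit, as do the two other measured compounds: the limit of > 25000 nM in this assay, at which 3 of the 3 values shown sit. Going by the values given here, no step between two measured compounds is available, so the numbers themselves show nothing about the size of any change.

Compound 4, `Cc1nc(Nc2ncco2)nc(N[C@@H]2C[C@H](CO)[C@@H](O)[C@H]2O)c1-c1nc2ccccc2s1`, is not yet measured. It differs from compound 3 in one place: 1,3-oxazol-2-yl in place of cyclobutylmethyl on a nitrogen on an aromatic ring.

Among the compounds with values here, with every measured value a limit and no measured step to lean on, no change beyond the scatter is expected in this assay. The expected step is a step that the limit leaves unreadable from compound 3 to compound 4. Compound 4 is estimated at 30000 nM, within a range from 10000 nM to 100000 nM, most likely again reported as a limit.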

Compound 4, half-maximal cytotoxic concentration: > 25000 nM
Compound 4 was reported as a limit; the forecaster's own chance of this, stated with the estimate: 85%; the middle value lies beyond the limit too.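

In this assay, no step can be read from compound 3 to compound 4, because both values are limits: the limit of > 25000 nM in this assay, at which 4 of the 4 values shown sit. The compounds shown leave open at what concentration any of them becomes cytotoxic, and whether 1,3-oxazol-2-yl and cyclobutylmethyl differ on this read-out.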